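The compounds below may be only part of what the source reports. "The series", "measured", "known", "first", "only" and "open" are said of these compounds alone.

Working notes on the series. Compound 2 `CCCCCc1ccc(-c2cn(C[C@H](O)[C@H]3OC(=O)C(OCc4ccccc4)=C3OCc3ccccc3)nn2)cc1` has the lowest number of the two measured compounds: in a functional assay on MCF7 cells (Homo sapiens) for antiproliferative activity, read by MTT assay, with a stated time of 72 h (a higher number here means a weaker inhibitor, a lower number a stronger inhibitor), compound 2 gives 9010 nM. Compound 1 `O=C1O[C@H]([C@@H](O)Cn2cc(-c3cc(C(F)(F)F)cc(C(F)(F)F)c3)nn2)C(OCc2ccccc2)=C1OCc1ccccc1` carries a different group on the same position, and in this assay compound 1 gives 45900 nM, a higher number than that of compound 2, with a gap that lies beyond the usual scatter. For the measured compounds named here, no step between these two is worked out here; the two values only show that the substituent on the five-membered aromatic ring with 3 nitrogen matters for the read-out.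

Compound 3 `O=C1O[C@H]([C@@H](O)Cn2cc(CNS(=O)(=O)c3ccc(Cl)cc3)nn2)C(OCc2ccccc2)=C1OCc1ccccc1` is not yet measured. It differs from compound 2 in one place: (((4-chlorophenyl)sulfonyl)amino)methyl in place of 4-pentylphenyl on an aromatic carbon. The change trades the 4-pentylphenyl for a group that is joined through a methylene and brings a sulfonamide with its hydrogen-bond donor and two acceptors.

With only two data points, the direction of the step is uncertain. Compound 3 is expected to give a higher number than compound 2, since the move away from a directly attached carbon ring in compound 1 with 45900 nM already gave a weaker value; the expected step is a 2.4-fold higher number from compound 2 to compound 3 (0.39 log units; beyond the scatter). The estimate for compound 3 in this assay is 22000 nM, with a range from 6000 nM to 80000 nM.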

Compound 3, half-maximal inhibitory concentration: 4170 nM
Beside the measured number, compound 3's estimate is 5.3-fold (0.72 log units) above it, outside the stated range (below it).
By their numbers in this assay, from the lowest: compound 3; then compound 2; then compound 1.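

Replacing 4-pentylphenyl with (((4-chlorophenyl)sulfonyl)amino)methyl on this aromatic carbon gives a 2.2-fold lower number from compound 2 to compound 3 (0.33 log units; beyond the scatter) in this assay and makes compound 3 the lowest of the three compounds, although the step is modest. The position therefore does not need an aromatic ring joined directly to the five-membered aromatic ring with 3 nitrogen, nor a pentyl chain, since a group joined through a methylene and carrying a sulfonamide also gives a lower number than compound 2. No measurement is at hand that explains the change in the read-out.

The compounds shown leave open which part of the new group accounts for the step, as the methylene, the sulfonamide and the chlorine all change together with the removal of the 4-pentylphenyl. A carboxamide in place of the sulfonamide, a methyl group on the sulfonamide nitrogen, or a bromine or methoxy group in place of the chlorine would each separate one of these parts from the others.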